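Fluoro on the fused ring of compound 2

The source may report more compounds than this note shows. Statements on the series, on what has been measured and on what is new or still open speak of the compounds shown alone.

Among the compounds with values here, compound 2 `CCc1cc(Nc2nc(N[C@@H](C)c3ccc(F)cc3)nc3ccccc23)n[nH]1` gives 120 nM in an assay on isolated protein for inhibition of G protein-coupled receptor kinase 6 (Homo sapiens), read by scintillation counting, radiometric assay and 33P incorporation, with a stated time of 80 min, in the presence of a further agent that is not named here (a lower number here means a stronger inhibitor, a higher number a weaker inhibitor), and holds the lowest of the three numbers measured so far. Compound 3 `CCc1cc(Nc2nc(N[C@@H](C)c3ccc(F)cc3)nc3ccc(OC)cc23)n[nH]1` gives 140 nM, and the step of a 1.2-fold higher number from compound 2 to compound 3 (0.07 log units; within the scatter) lies within the scatter. Compound 1 `CCc1cc(Nc2nc(N[C@@H](C)c3cccc(F)c3)nc3ccccc23)n[nH]1` gives 340 nM, and the step of a 2.8-fold lower number from compound 1 to compound 2 (0.45 log units; beyond the scatter) is beyond the scatter.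

Compound 4 `CCc1cc(Nc2nc(N[C@@H](C)c3ccc(F)cc3)nc3cccc(F)c23)n[nH]1` differs from compound 2 by fluoro in place of hydrogen on an aromatic carbon. The step from compound 2 to compound 3 bears most directly on this change, since it also places a substituent on the same fused ring; that step stayed within the scatter. The step from compound 1 to compound 2 concerns the fluorophenyl group instead and so speaks less to this change. On this basis no step beyond the scatter is expected in this assay for compound 4.

Compound 4 is therefore estimated at 130 nM, with a range of 50 nM to 340 nM, which means an expected step of a 1.1-fold higher number from compound 2 to compound 4 (0.03 log units; within the scatter).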

Compound 4, half-maximal inhibitory concentration: 41 nM
Compound 4: middle estimate off by 3.2-fold (0.50 log units), on the high side, outside the stated range (below it).
By their numbers in this assay, from the lowest: compound 4; then compounds 2 and 3 (each within the scatter of the next); then compound 1.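

In this assay, fluoro in place of hydrogen on this aromatic carbon, ortho to a fused ring and meta to a fused ring, gives a 2.9-fold lower number from compound 2 to compound 4 (0.47 log units; beyond the scatter), a modest step. The earlier 1.2-fold higher number from compound 2 to compound 3 (0.07 log units; within the scatter), with methoxy on another carbon of the same ring, had left that ring looking indifferent to substitution; compound 4 shows that a single fluorine atom on this ring can move the number beyond the scatter. No available evidence accounts for this step.

Whether the step belongs to fluoro alone stays open, since the compounds shown do not say how chloro, methyl or an amine would read on the same carbon. Also open, on these data alone, is whether it would carry over to a compound bearing the 3-fluorophenyl group of compound 1.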